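Swapping Chloro for Methoxy: Expected Shift on a Shared Core

The source may hold more compounds than are shown below. What is called first, only, known or untested is meant among the compounds shown, and "the series" means these compounds.

Of the compounds shown here, three with a shared core have been measured in a functional assay on CHO cells for agonist activity at Alpha-1A adrenergic receptor (Homo sapiens), read by FLIPR and calcium flux; a higher number here means that more compound is needed for the effect, a lower number that less compound is needed. Compound 1 `COc1cccc(C2CCc3nc[nH]c3C2)c1` gives 1050 nM, compound 2 `Clc1ccccc1C1CCc2nc[nH]c2C1` gives 276 nM, and compound 3 `Clc1cccc(C2CCc3nc[nH]c3C2)c1` gives 514 nM. Compounds 2 and 3 have the same atoms joined differently; how their cores differ is not broken down here, and their two values lie within the scatter of each other. From compound 3 to compound 1 the change is methoxy in place of chloro on an aromatic carbon, and it produced a 2.0-fold higher number from compound 3 to compound 1 (0.31 log units; beyond the scatter). Compound 4 `COc1ccccc1C1CCc2nc[nH]c2C1`, not yet measured, arises from compound 2 by methoxy in place of chloro on an aromatic carbon; this is the same kind of change, but here the methoxy sits ortho to a group of 9 heavy atoms rather than meta to it. Because the step of a 2.0-fold higher number from compound 3 to compound 1 (0.31 log units; beyond the scatter) was modest, the expected step in this assay is a 2.0-fold higher number from compound 2 to compound 4 (0.30 log units; within the scatter). Compound 4 is therefore estimated at 550 nM, between 250 nM and 1200 nM.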

Compound 4, half-maximal effective concentration: 144 nM
Beside the measured number, compound 4's estimate is 3.8-fold (0.58 log units) above it; the measured number lies below the stated range.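

In this assay, methoxy in place of chloro, here on an aromatic carbon ortho to a group of 9 heavy atoms, gave a 1.9-fold lower number from compound 2 to compound 4 (0.28 log units; within the scatter). Within the data shown here, the same change therefore did not carry over unchanged from one core to the other: the same change on two cores in this assay, a 2.0-fold higher number (0.31 log units; beyond the scatter) from compound 3 to compound 1 and a 1.9-fold lower number (0.28 log units; within the scatter) from compound 2 to compound 4, 3.9-fold (0.59 log units) apart, beyond the scatter of two such steps This shows that, in this series, the step seen on one core cannot simply be transferred to another, but it does not show why the two steps differ, and with only one pair on each core it supports no general rule.

The compounds shown leave open whether an amine or a longer chain such as ethoxy in place of chloro would follow the course seen on the core of compound 1 or that seen on the core of compound 2. They also leave open whether the same gap between the two steps would appear on any further core.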